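Moving the Pyridyl Nitrogen on a Shared Sulfonamide Core

The source may hold more compounds than are shown below. What is called first, only, known or untested is meant among the compounds shown, and "the series" means these compounds.

compound 1 `Cc1ccc(S(=O)(=O)N(CC(=O)NCc2ccc(Cl)cc2)c2cccnc2C)cc1`: 676 nM
compound 2 `Cc1ccc(S(=O)(=O)N(CC(=O)NCc2ccc(Cl)cc2)c2ncccc2C)cc1`: < 1450 nM

In a functional assay on CHO-K1 cells for antagonist activity at prostaglandin E2 receptor EP1 subtype (Homo sapiens), read by FLIPR and calcium flux (on this read-out higher numbers stand for weaker inhibition and lower numbers for stronger inhibition), compound 1 gives 676 nM. For compound 2 the reported value < 1450 nM is a limit of this assay and not a number. One of the two values shown sits at the limit of < 1450 nM in this assay, at which 1 of the 2 values shown sits. Among the compounds with values here, the only measured step, a step that the limit leaves unreadable from compound 1 to compound 2, is therefore of unreadable size, and compound 2 cannot be placed more closely than that limit allows.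

Compound 3 `Cc1ccc(S(=O)(=O)N(CC(=O)NCc2ccc(Cl)cc2)c2ccc(C)nc2)cc1` differs from compound 2 by 6-methylpyridin-3-yl in place of 3-methylpyridin-2-yl on a sulfonamide nitrogen. Within the data shown here, the one step that bears on this change is the unreadable one from compound 1 to compound 2, so no size can be taken from it, and the only number in hand is that of compound 1. With nothing in the data pointing to a shift beyond the scatter, the step that the limit leaves unreadable from compound 2 to compound 3 is expected to stay within the usual spread of such measurements. Compound 3 is estimated to give 800 nM in this assay, within a range from 250 nM to 2500 nM.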

Compound 3, inhibition constant: < 1450 nM
Compound 3 gave a limit, no number (the forecaster's own chance of this, stated with the estimate: 20%); the middle value is on the limit's open side.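

In this assay compound 3 gives < 1450 nM, which is a limit and not a number. No step among compound 1, compound 2 and compound 3 can be read, and the values share one limit: the limit of < 1450 nM in this assay, at which 2 of the 3 values shown sit.

The compounds shown leave open whether 2-methylpyridin-3-yl, 3-methylpyridin-2-yl and 6-methylpyridin-3-yl on the sulfonamide nitrogen differ at all in inhibition.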